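Furan for methoxynaphthyl on the shared core

The source may report more compounds than this note shows. Statements on the series, on what has been measured and on what is new or still open speak of the compounds shown alone.

Three analogues of one core have been run in a functional assay on Ehrlich cells (Mus musculus) for cytotoxicity; a lower number here means a stronger inhibitor, a higher number a weaker inhibitor. Compound 1 `COc1cc(N2C(N)=C(C#N)C(c3ccc([N+](=O)[O-])cc3)C3=C2CC(C)(C)CC3=O)cc(OC)c1OC` gives 25000 nM in this assay. Compound 2 `COc1cc(N2C(N)=C(C#N)C(c3c(OC)ccc4ccccc34)C3=C2CC(C)(C)CC3=O)cc(OC)c1OC` is reported in this assay as "not active" (no number reported), with no number behind it. Compound 3 `COc1cc(N2C(N)=C(C#N)C(c3cccc([N+](=O)[O-])c3)C3=C2CC(C)(C)CC3=O)cc(OC)c1OC` likewise comes back in this assay as "not active" (no number reported). On the numbers shown, compound 2 therefore stands without a single value, and one further entry, compound 3, is in the same position. Among the compounds with values here, compound 4 `COc1cc(N2C(N)=C(C#N)C(c3ccc(C)o3)C3=C2CC(C)(C)CC3=O)cc(OC)c1OC` has not been measured; it differs from compound 2 as follows: 5-methylfuran-2-yl in place of 2-methoxynaphthalen-1-yl on a saturated ring carbon No step between measured compounds is available, so only the weak level of compound 1 at 25000 nM anchors the series; a step from compound 2 to compound 4 in this assay of no more than the usual scatter, in either direction, is expected. Compound 4 is estimated at 30000 nM in this assay, within 8000 nM to 120000 nM, with a real chance that only inactivity is reported.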

Compound 4, half-maximal inhibitory concentration: 216000 nM
The estimate for compound 4 lay 7.2-fold (0.86 log units) below the measured number; the measured number lies above the stated range.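

In this assay, within the data shown here, 5-methylfuran-2-yl in place of 4-nitrophenyl on the saturated ring carbon gives an 8.6-fold higher number from compound 1 to compound 4 (0.94 log units; beyond the scatter), the first readable step at this position, and it points to a still weaker number. Steps involving compound 2 or compound 3 cannot be read, since neither has a single value. Nothing available bears on the reason for this step.

Still open, as far as these compounds go, is whether the furan ring or its methyl group accounts for the step, which unsubstituted furan-2-yl would address. Also open, from the compounds shown here alone, is how a 4-aminophenyl or 4-carboxyphenyl group at this carbon would read in this assay.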